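Aryl change from compound 3 to compound 4

The source may report more compounds than this note shows. Statements on the series, on what has been measured and on what is new or still open speak of the compounds shown alone.

Measured in a functional assay on FM3A cells (Mus musculus) for antiproliferative activity; on this read-out lower numbers stand for stronger inhibition and higher numbers for weaker inhibition:
- compound 1 `COc1cc(C(=O)c2sc(-c3ccc(Cl)c(Cl)c3)cc2N)cc(OC)c1OC` gives 400 nM
- compound 2 `COc1cc(C(=O)c2sc(-c3ccc(F)cc3)cc2N)cc(OC)c1OC` gives 16 nM
- compound 3 `COc1cccc(-c2cc(N)c(C(=O)c3cc(OC)c(OC)c(OC)c3)s2)c1` gives 36 nM

Compound 3 holds the second highest number of the three, with compound 2 lower and compound 1 higher. Unmeasured compound 4 `COc1cc(C(=O)c2sc(-c3ccc(C)cc3)cc2N)cc(OC)c1OC` carries 4-methylphenyl in place of 3-methoxyphenyl on an aromatic carbon. The nearest guide is the modest 2.3-fold higher number from compound 2 to compound 3 (0.35 log units; beyond the scatter), which also starts from a 4-substituted phenyl. The large 25-fold lower number from compound 1 to compound 2 (1.40 log units; beyond the scatter) and the large 11-fold lower number from compound 1 to compound 3 (1.05 log units; beyond the scatter) both leave 3,4-dichlorophenyl and bear less directly. A small move to a lower number is therefore expected in this assay, possibly within the scatter. The estimated change is a 1.4-fold lower number from compound 3 to compound 4 (0.16 log units; within the scatter) overall. Compound 4 is expected at 25 nM (estimated range 8 nM to 80 nM).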

Compound 4, half-maximal inhibitory concentration: 16 nM
The estimate for compound 4 lay 1.6-fold (0.19 log units) above the measured number; the range from low to high includes it.
By their numbers in this assay, from the lowest: compounds 2 and 4 (each within the scatter of the next); then compound 3; then compound 1.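

In this assay, 4-methylphenyl and 4-fluorophenyl are not separated, with no change at the digits printed from compound 2 to compound 4 (within the scatter), so methyl and fluoro on this phenyl read alike here. Both 3-methoxyphenyl and 3,4-dichlorophenyl stand apart from 4-methylphenyl, with a 2.3-fold lower number from compound 3 to compound 4 (0.35 log units; beyond the scatter) and a 25-fold lower number from compound 1 to compound 4 (1.40 log units; beyond the scatter). No evidence is at hand on what lies behind these steps.

Still open, on these data alone, is whether 4-methoxyphenyl would stay level with 4-methylphenyl, which would show whether the 3-methoxyphenyl step follows the group or its place. Also open, as far as these compounds go, is how a 4-aminophenyl or a longer chain such as 4-butylphenyl would read.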